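The source may report more compounds than this note shows. Statements on the series, on what has been measured and on what is new or still open speak of the compounds shown alone.

In a functional assay on MDA-MB-231 cells (Homo sapiens) for antiproliferative activity, read by MTT assay, with a stated time of 96 h (on this read-out lower numbers stand for stronger inhibition and higher numbers for weaker inhibition), compound 1 (`CC(C)=CCC/C(C)=C/CC/C(C)=C/CC[C@]1(C)CCc2c(C)c(OC(=O)NS(=O)(=O)c3ccc(Cl)cc3)c(C)c(C)c2O1`) reads > 10000 nM as a limit of the assay and not a number. Compound 3 (`CC(C)=CCC/C(C)=C/CC/C(C)=C/CC[C@]1(C)CCc2c(C)c(OC(=O)NS(=O)(=O)c3ccc(C)cc3)c(C)c(C)c2O1`) also reads > 10000 nM as a limit of the assay. Going by the values given here, compound 2 (`CC(C)=CCC/C(C)=C/CC/C(C)=C/CC[C@]1(C)CCc2cc(OC(=O)NS(=O)(=O)c3ccc(C)cc3)cc(C)c2O1`) gives 6600 nM as the only actual number so far.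

The step under review leads to compound 4 (`CC(C)=CCC/C(C)=C/CC/C(C)=C/CC[C@]1(C)CCc2c(C)c(OC(=O)Nc3ccccc3)c(C)c(C)c2O1`) and puts phenyl in place of (4-chlorophenyl)sulfonyl on an amide-type nitrogen so that ((4-chlorophenyl)sulfonyl)amino becomes anilino. Among the compounds with values here, the one measured step, a step that the two limits leave unreadable from compound 1 to compound 3 with methyl in place of chloro on an aromatic carbon, keeps the sulfonyl and has no readable size, so no measured step speaks directly to this change.

The starting point of compound 1 is the limit of > 10000 nM in this assay, at which 2 of the 3 values shown sit, and offers no number to move from. No step beyond the scatter is therefore expected in this assay and no direction can be claimed firmly. The step expected is a step that the limit leaves unreadable from compound 1 to compound 4 and a limit of the assay is the likeliest expected outcome. For compound 4 the estimated value is 12000 nM with an expected range from 5000 nM to 30000 nM in this assay when measured.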

Compound 4, half-maximal inhibitory concentration: > 10000 nM
Compound 4 was reported as a limit (the forecaster's own chance of this, stated with the estimate: 75%); the middle value does not contradict the limit.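

In this assay compound 4 gives > 10000 nM, a limit of the assay and not a number. No new step can be read from compound 1 or compound 3 to compound 4, because each pair has limits at both ends: the limit of > 10000 nM in this assay, at which 3 of the 4 values shown sit.

The compounds shown leave open whether phenyl in place of (4-chlorophenyl)sulfonyl on the amide-type nitrogen changes the read-out in this assay at all.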